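Tetrazole in Place of the Carboxylic Acid on the Cyclopropane

A few compounds are considered here, and "the series" means these few. Any claim that something is new, unique, unknown or untested is made for them only; others in the source may bear on it.

Compound 1 `O=C(O)c1cncc(C2CC2c2ccc(OCc3c(-c4c(Cl)cccc4Cl)noc3C3CC3)cc2Cl)c1` gives 73% in an assay on HEK293 cells for agonist activity at Bile acid receptor (Homo sapiens); on this read-out higher numbers stand for larger maximal responses and lower numbers for smaller maximal responses. Of the three numbers measured it holds the second highest place, yet compound 3 `O=C(O)c1cncc(N2CC(O)(c3ccc(OCc4c(-c5c(Cl)cccc5Cl)noc4C4CC4)cc3Cl)C2)c1` with 71% and compound 2 `CC(C)n1nc(C(=O)O)cc1[C@@H]1C[C@H]1c1ccc(OCc2c(-c3c(Cl)cccc3Cl)noc2C2CC2)cc1Cl` with 79% both lie within the usual scatter of compound 1, so the three cannot be told apart. Compound 4 `Clc1cc(OCc2c(-c3c(Cl)cccc3Cl)noc2C2CC2)ccc1C1CC1c1ccc(-c2nnn[nH]2)nc1` is not yet measured. It differs from compound 1 by 6-(1H-tetrazol-5-yl)pyridin-3-yl in place of 5-carboxypyridin-3-yl on a saturated ring carbon. Among the measured compounds shown here, no step between measured compounds is at hand to guide this change. The three measured values cluster closely, and the step from compound 1 to compound 4 is therefore expected to be a number 1 percentage points lower from compound 1 to compound 4 (within the scatter) in this assay, none beyond the scatter. Compound 4 is estimated to reach 72%, with a range from 55% to 90%.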

Compound 4, largest response reached (reported as efficacy), in percent of the reference or control that the assay uses: 79%
Compound 4: the middle estimate sits 7 percentage points below what was measured, and the stated range covers the measured number.
By their numbers in this assay, from the lowest: compounds 3, 1, 2 and 4 (each within the scatter of the next).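

With a number 6 percentage points higher from compound 1 to compound 4 (within the scatter) in this assay, the change to 6-(1H-tetrazol-5-yl)pyridin-3-yl on this saturated ring carbon leaves the maximal response within the scatter. This is the first step shown at this position, and it shows that the response holds there without a carboxylic acid, with a tetrazole in its place. Nothing measured here bears on why the response holds. From the compounds shown here alone, whether a primary amide or a sulfonamide on the pyridine would also hold it stays open, as does the effect of the tetrazole in place of the carboxylic acid of compound 2 or compound 3.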